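Swapping Trifluoromethyl for Hydroxy on a Shared Core

This account rests on a few compounds, and the source may have more. Where it says the series, first, only, none or still open, it means among the compounds named here.

Of the compounds shown here, three built on one shared core have been tested in an ADME assay on NIH3T3 cells (Mus musculus) for cytotoxicity, read by XTT assay, with a stated time of 24 h; a higher number here means a weaker inhibitor, a lower number a stronger inhibitor. Compound 1 `Cn1nnnc1SCC(=O)N/N=C/c1ccc([N+](=O)[O-])cc1` gives 9300000 nM in this assay. Compound 2 `Cn1nnnc1SCC(=O)N/N=C/c1ccc(Br)cc1` gives 10000000 nM in this assay. For compound 3 `Cn1nnnc1SCC(=O)N/N=C/c1ccc(C(F)(F)F)cc1` this assay reports only a limit, > 10000000 nM, and not a number. Compound 3 therefore stands at the edge of what the method can report, (the limit of > 10000000 nM in this assay, at which 1 of the 3 values shown sits), with no number of its own to set beside the others. The change to compound 4 `Cn1nnnc1SCC(=O)N/N=C/c1ccc(O)cc1` is hydroxy in place of trifluoromethyl on an aromatic carbon. The measured steps that bear on this change all swap groups on the same aromatic carbon. As a 1.1-fold higher number from compound 1 to compound 2 (0.03 log units; within the scatter) and an at least 1.0-fold higher number from compound 1 to compound 3 (0.03 log units; that floor lies within the scatter) stayed within the scatter, and a number no lower from compound 2 to compound 3 (the limit leaves the size open) left the size open, the step of a number no higher from compound 3 to compound 4 (the limit leaves the size open) is expected to stay within the scatter as well, in no particular direction. Compound 4 is accordingly estimated at 10000000 nM, with a range from 3000000 nM to 30000000 nM, and this assay may once more report only a limit.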

Compound 4, half-maximal inhibitory concentration: 632000 nM
Beside the measured number, compound 4's estimate is 16-fold (1.20 log units) above it, outside the stated range (below it).
By their numbers in this assay, from the lowest: compound 4; then compounds 1 and 2 (each within the scatter of the next).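

In this assay, the group on this aromatic carbon turns out to matter: hydroxy gives a 16-fold lower number from compound 2 to compound 4 (1.20 log units; beyond the scatter) and a 15-fold lower number from compound 1 to compound 4 (1.17 log units; beyond the scatter), whereas no earlier swap among nitro, bromo and trifluoromethyl had shown a readable step beyond the scatter. Against trifluoromethyl, the change gives an at least 15-fold lower number from compound 3 to compound 4 (1.19 log units; beyond the scatter), so this size is a floor and the full step may be larger. Compound 3 has a limit of the assay and not a number: the limit of > 10000000 nM in this assay, at which 1 of the 4 values shown sits.

The compounds shown leave open whether this large step belongs to hydroxy alone or would also appear with an amine or a methoxy group on the same aromatic carbon. They also give no measured property that could explain why the number falls with hydroxy.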